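Capping the hydroxy group on the cyclohexyl member

A few compounds are considered here, and "the series" means these few. Any claim that something is new, unique, unknown or untested is made for them only; others in the source may bear on it.

In an ADME assay on S9 fraction from liver (Homo sapiens) for metabolic stability, with a stated time of 1 h (a lower number here means that less of the compound is left, a higher number that more of the compound is left), compound 1 `N#Cc1cnc(NCc2cnccc2C(F)(F)F)cc1N[C@H]1C[C@@H](O)C1` gives 90% and compound 2 `N#Cc1cnc(NCc2cnccc2C(F)(F)F)cc1NC[C@H]1C[C@H](O)C1` gives 93%. The comparison of these two, a number 3 percentage points higher from compound 1 to compound 2 (within the scatter), stays inside the scatter. Compound 3 `N#Cc1cnc(NCc2cnccc2C(F)(F)F)cc1N[C@H]1CC[C@@H](O)CC1` gives 33%, the lowest of the three numbers. Its gap to the other two is large: a number 57 percentage points lower from compound 1 to compound 3 (beyond the scatter), and a number 60 percentage points lower from compound 2 to compound 3 (beyond the scatter).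

Compound 4 `CO[C@H]1CC[C@@H](Nc2cc(NCc3cnccc3C(F)(F)F)ncc2C#N)CC1` differs from compound 3 by methyl in place of hydrogen on an oxygen on a saturated carbon, which reads as hydroxy to methoxy, or 4-hydroxycyclohexyl to 4-methoxycyclohexyl. Among the compounds with values here, none of the measured steps makes this change. All three exchange the whole group on a nitrogen on an aromatic ring, while the hydroxy group itself stays in place, so the data give no direct size for a methyl in place of hydrogen on that oxygen. The large steps do show that the choice of this group can move this assay a long way, so the uncertainty is kept wide. Compound 4 keeps the cyclohexyl group of compound 3, which sets the starting point at 33%. The expected change is a number 3 percentage points lower from compound 3 to compound 4 (within the scatter), which means no step beyond the scatter is expected. The estimate for compound 4 is 30%, with an expected range from 12% to 55%.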

Compound 4, percent of the compound remaining: 19%
For compound 4 the middle estimate is 11 percentage points above the measured one, and the stated range covers the measured number.
By their numbers in this assay, from the lowest: compound 4; then compound 3; then compounds 1 and 2 (each within the scatter of the next).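

Methyl in place of hydrogen on an oxygen on a saturated carbon now has a direct reading on the cyclohexyl member: in this assay the change to 4-methoxycyclohexyl gives a number 14 percentage points lower from compound 3 to compound 4 (beyond the scatter) as a modest step, so the hydroxy hydrogen at this position does bear on the read-out. Capping also leaves the cyclohexyl member no closer to the cyclobutyl members, with a number 71 percentage points lower from compound 1 to compound 4 (beyond the scatter) and a number 74 percentage points lower from compound 2 to compound 4 (beyond the scatter) as large steps, and the choice of the whole group on the nitrogen stays the larger lever in this small set. Nothing available here accounts for the drop on capping.

Open, as far as these compounds go, is whether the same methyl on the oxygen of the 3-hydroxycyclobutyl or (3-hydroxycyclobutyl)methyl members would also lower the number, or whether the step holds only for the cyclohexyl member. Also open, from the compounds shown here alone, is where an amine or a carboxylic acid in place of the hydroxy group on the cyclohexyl member would fall in this assay relative to compound 3 and compound 4.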